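Swapping methoxy for fluoro on a quiet compound

The compounds below may be only part of what the source reports. "The series", "measured", "known", "first", "only" and "open" are said of these compounds alone.

Measured so far:
compound 1 `Cc1ccc(-c2nc3c(=O)[nH]c(C)nc3s2)cc1` gives 17%
compound 2 `Cc1nc2sc(-c3ccc(F)cc3)nc2c(=O)[nH]1` gives 1%
compound 3 `COc1cccc(-c2nc3c(=O)[nH]c(C)nc3s2)c1` gives 1%

All three were tested in an assay on CHO cells for displacement of a labelled ligand from adenosine receptor A1 (Homo sapiens), read by scintillation counting, with a stated time of 120 min, tested at 1 uM (a lower number here means less inhibition, a higher number more inhibition at the concentration tested (going by the name of the read-out)), where compound 3 gives 1%. That puts compound 3 level with compound 2 at the digits shown, the two together at the bottom of the three numbers, and a clear distance below compound 1, which is the only compound here to show inhibition beyond the scatter.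

The next compound, compound 4 `Cc1nc2sc(-c3cccc(F)c3)nc2c(=O)[nH]1`, differs from compound 3 by fluoro in place of methoxy on an aromatic carbon. Among the compounds with values here, only one measured step involves a fluoro entering an aromatic carbon: a number 16 percentage points lower from compound 1 to compound 2 (beyond the scatter). Within the data shown here, that step started from the one compound with a visible signal and ended at the floor, so it says little about a change that starts from a compound already at the floor. Among the measured compounds shown here, compound 2, which carries a fluoro, and compound 3, which carries a methoxy, both sit at the bottom, so nothing among the measured compounds points to a rise when the methoxy is replaced by a fluoro.

Compound 4 is therefore expected to show essentially no movement in this assay , a number 2 percentage points higher from compound 3 to compound 4 (within the scatter). The estimate for compound 4 is 3%, within -6% to 13%.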

Compound 4, a percentage reported as inhibition, at one concentration (the size of the read-out at that concentration, not a potency): 1%
Compound 4: the middle estimate sits 2 percentage points above what was measured; the range from low to high includes it.
By their numbers in this assay, from the lowest: compounds 2, 3 and 4 (each within the scatter of the next); then compound 1.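

Replacing methoxy with fluoro on this aromatic carbon, meta to a large group, gives no change at the digits printed from compound 3 to compound 4 (within the scatter) in this assay. Within the data shown here, this is the first direct look at a change in this place, and it shows that the larger group, which counts one hydrogen-bond acceptor, can give way to a single fluorine without the reading leaving the bottom of the range, whereas the earlier fluoro step began from the one compound with a visible signal. Among these compounds, both ends of this step sit near zero, however, so the result shows only that neither group brings out inhibition at the concentration tested, and nothing measured here explains that or shows whether the two groups would still match on a compound with a stronger signal.

Going by these compounds, it remains open whether an amine, a carboxylic acid or a longer chain such as propyl on this same aromatic carbon would lift the number clear of the scatter. Also open, on these data alone, is whether any group in this place could reach the level of compound 1, which carries a methyl and gives 17%.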